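Series notes: chain substituent on the shared core, compound 4

The source may report more compounds than this note shows. Statements on the series, on what has been measured and on what is new or still open speak of the compounds shown alone.

Compound 2 `NCC(O)Cn1c(=O)n(C2OC(CO)[C@@H](O)[C@H]2O)c2nc(N)nc(O)c21` stands highest among the three measured compounds in a functional assay on the whole organism (B cells) with Mus musculus as the target (on this read-out lower numbers stand for smaller maximal responses and higher numbers for larger maximal responses), giving 110%. Compound 1 `CCn1c(=O)n(C2OC(CO)[C@@H](O)[C@H]2O)c2nc(N)nc(O)c21` gives 82% in this assay, and compound 3 `C=CCn1/c(=N\C#N)n([C@H]2OC(CO)[C@@H](O)[C@H]2O)c2cc(N)nc(O)c21` gives 85%. For the measured compounds named here, the only measured step on the chain bound to the aromatic nitrogen is a number 28 percentage points higher from compound 1 to compound 2 (beyond the scatter). Compound 4 `Nc1nc(O)c2c(n1)n(C1OC(CO)[C@@H](O)[C@H]1O)c(=O)n2CC(O)CSc1ccccc1` differs from compound 2 by phenylsulfanyl in place of amino on a saturated chain carbon, two bonds along the chain from an oxygen on a saturated carbon. Going by the values given here, no measured pair shows this change, so the step from compound 1 to compound 2 is the only guide, and it concerns a different part of the chain. The expected step is therefore a number 15 percentage points lower from compound 2 to compound 4 (beyond the scatter), a decrease that may not lie beyond the scatter. Compound 4 is estimated at 95% in this assay, within 60% to 125%.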

Compound 4, largest response reached (reported as maximal response), in percent of the reference or control that the assay uses: 12%
Compound 4: the middle estimate sits 83 percentage points above what was measured, outside the stated range (below it).
By their numbers in this assay, from the lowest: compound 4; then compounds 1 and 3 (each within the scatter of the next); then compound 2.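

At this chain end the size of the change is large: in this assay phenylsulfanyl in place of amino gives a number 98 percentage points lower from compound 2 to compound 4 (beyond the scatter). The chain can therefore move the response in either direction, since 1-hydroxy-2-(phenylsulfanyl)ethyl in place of methyl gives a number 70 percentage points lower from compound 1 to compound 4 (beyond the scatter), against a number 28 percentage points higher from compound 1 to compound 2 (beyond the scatter) for 2-amino-1-hydroxyethyl. Nothing at hand bears on why the response falls.

Open, going by these compounds, is whether the sulfur or the phenyl ring goes with the loss. A phenoxy group or a plain phenyl group on the same chain carbon would separate the two.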